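From hydroxy to methyl: what compound 4 may show

The source may report more compounds than this note shows. Statements on the series, on what has been measured and on what is new or still open speak of the compounds shown alone.

Measured in a functional assay on HepG2 cells (Homo sapiens) for inhibition, read by MTT assay, with a stated time of 48 h; a lower number here means a stronger inhibitor, a higher number a weaker inhibitor:
Compound 1 `COc1cc(-c2nccn3cc(-c4ccc(Cl)cc4)nc23)cc(OC)c1OC`: 475 nM
Compound 2 `COc1cc(-c2nccn3cc(-c4ccc(C(F)(F)F)cc4)nc23)cc(OC)c1OC`: 2630 nM
Compound 3 `COc1cc(-c2nccn3cc(-c4ccc(O)cc4)nc23)cc(OC)c1OC`: 823 nM

Compound 3 gives a clearly lower number than compound 2 and lies within the scatter of compound 1. Compound 4 `COc1cc(-c2nccn3cc(-c4ccc(C)cc4)nc23)cc(OC)c1OC` keeps the shared core and changes one group: methyl in place of hydroxy on an aromatic carbon. Two measured swaps at this same place involve hydroxy. There is a 1.7-fold higher number from compound 1 to compound 3 (0.24 log units; within the scatter), within the scatter, and a 3.2-fold lower number from compound 2 to compound 3 (0.50 log units; beyond the scatter), a modest step. Methyl itself is untested here, so neither direction is favoured, and no step beyond the scatter is expected. The expected step is a 1.0-fold lower number from compound 3 to compound 4 (0.01 log units; within the scatter). Compound 4 is estimated at 800 nM, with an expected range from 350 nM to 2000 nM.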

Compound 4, half-maximal inhibitory concentration: 160 nM
The estimate for compound 4 lay 5.0-fold (0.70 log units) above the measured number; measured number below the stated range.
By their numbers in this assay, from the lowest: compound 4; then compounds 1 and 3 (each within the scatter of the next); then compound 2.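

In this assay, methyl stands clearly apart from both hydroxy and chloro at this position, with a 5.1-fold lower number from compound 3 to compound 4 (0.71 log units; beyond the scatter) and a 3.0-fold lower number from compound 1 to compound 4 (0.47 log units; beyond the scatter), although those two groups lie within the scatter of each other. The widest gap is to trifluoromethyl, with a 16-fold lower number from compound 2 to compound 4 (1.22 log units; beyond the scatter), which shows that a single group at this position can shift the number considerably. Nothing available explains why methyl gives the lowest number of the four. From the compounds shown here alone, whether an ethyl group, a longer chain or an amine at this position would match compound 4 remains open.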